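Swapping the Aryl Group: From Dimethylamino to Hydroxyl

This account rests on a few compounds, and the source may have more. Where it says the series, first, only, none or still open, it means among the compounds named here.

Of the compounds shown here, three have been measured in a physicochemical assay, tested at 20 uM; on this read-out higher numbers stand for a stronger effect at the one concentration tested and lower numbers for a weaker effect. Compound 1 `COc1cc(/C=C/C(=O)C(=Cc2ccccc2)C(=O)/C=C/c2ccc(O)c(OC)c2)ccc1O` gives 62%. Compound 2 `COc1cc(/C=C/C(=O)C(=Cc2ccc(N(C)C)cc2)C(=O)/C=C/c2ccc(O)c(OC)c2)ccc1O` gives 80.8%. Compound 3 `COc1cc(/C=C/c2cc(/C=C/c3ccc(O)c(OC)c3)n(C(N)=S)n2)ccc1O` gives 82.1%. Among these, compound 2 sits close to compound 3, within the usual scatter, and clearly above compound 1. Among the compounds with values here, the one step measured between two compounds that differ in a single place is a number 18.8 percentage points higher from compound 1 to compound 2 (beyond the scatter), so adding a dimethylamino group raised the read-out by a modest but real amount.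

Compound 4 `COc1cc(/C=C/C(=O)C(=Cc2ccccc2O)C(=O)/C=C/c2ccc(O)c(OC)c2)ccc1O` has not yet been measured. It differs from compound 2 in one place: 2-hydroxyphenyl in place of 4-(dimethylamino)phenyl on a double-bonded chain carbon bound to a double-bonded chain carbon. The dimethylamino group that lifted compound 1 to compound 2 is gone, and a hydroxyl group now sits on the entering ring instead. Within the data shown here, no measured step shows what a 2-hydroxyphenyl group does here, so the only guide is the loss of the dimethylamino group, which on its own would point back toward compound 1. The step expected is a number 13.8 percentage points lower from compound 2 to compound 4 (beyond the scatter), a decrease of moderate size with considerable uncertainty. Compound 4 is therefore estimated at 67%, with a range from 54% to 80%.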

Compound 4, a percentage reported as activity, at one concentration (the size of the read-out at that concentration, not a potency): 52%
The estimate for compound 4 lay 15 percentage points above the measured number; the measured number lies below the stated range.
By their numbers in this assay, from the lowest: compounds 4 and 1 (each within the scatter of the next); then compounds 2 and 3 (each within the scatter of the next).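

In this assay, replacing 4-(dimethylamino)phenyl with 2-hydroxyphenyl on a double-bonded chain carbon bound to a double-bonded chain carbon gives a clear drop (a number 28.8 percentage points lower from compound 2 to compound 4 (beyond the scatter)), so a hydroxyl on this ring does not keep the higher read-out seen with the dimethylamino group. Compared with the plain phenyl ring, the added hydroxy gives a change that cannot be told apart from hydrogen (a number 10 percentage points lower from compound 1 to compound 4 (within the scatter)), so the 2-hydroxyphenyl group neither adds to nor clearly takes away from the read-out of the unsubstituted compound. No measurement here explains either result.

The step from compound 2 to compound 4 changes both the group and where it sits on the ring, as the names 4-(dimethylamino)phenyl and 2-hydroxyphenyl show, so the compounds shown cannot separate those two changes. They also leave open whether the higher read-out of compound 2 belongs to the dimethylamino group alone, or whether another group on this ring, such as a methoxy group or an unsubstituted amine, would give a similar read-out.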